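A Shared Core, From Compound 2 to Compound 4

This account rests on a few compounds, and the source may have more. Where it says the series, first, only, none or still open, it means among the compounds named here.

Of the compounds shown here, three sharing one core have been tested in an assay for inhibition of histone deacetylase 4 (Homo sapiens); on this read-out higher numbers stand for weaker inhibition and lower numbers for stronger inhibition. Compound 1 `O=C(c1ccc(-c2nc(-c3ccc(C(F)(F)F)cc3)no2)s1)C(F)(F)F` gives 200 nM, compound 2 `O=C(c1ccc(-c2nc(-c3cccnc3)no2)s1)C(F)(F)F` gives 70 nM, and compound 3 `O=C(c1ccc(-c2ncc(-c3ccccc3)s2)s1)C(F)(F)F` gives 1500 nM. Compound 2 has the lowest number, and its gaps to compound 1 and to compound 3 both lie beyond the usual scatter, so it is the strongest inhibitor of the three. Compound 4 `O=C(c1ccc(-c2nc(-c3ccc(F)cc3F)no2)s1)C(F)(F)F` is not yet measured and differs from compound 2 by 2,4-difluorophenyl in place of pyridin-3-yl on an aromatic carbon. Among the compounds with values here, no measured pair shows this exact change; compound 1, with a ring of carbon only, gives 200 nM, a weaker result than compound 2. The step of a 2.1-fold higher number from compound 2 to compound 4 (0.33 log units; beyond the scatter) is expected to be a modest weakening in this assay. Compound 4 is estimated at 150 nM, within a range from 50 nM to 450 nM.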

Compound 4, half-maximal inhibitory concentration: 120 nM
For compound 4 the middle estimate is 1.3-fold (0.10 log units) above the measured one; the measured number falls inside the stated range.
By their numbers in this assay, from the lowest: compounds 2, 4 and 1 (each within the scatter of the next, the first and the last beyond it); then compound 3.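

Putting 2,4-difluorophenyl in place of pyridin-3-yl on this aromatic carbon gives a 1.7-fold higher number from compound 2 to compound 4 (0.23 log units; within the scatter) in this assay, so the two compounds cannot be told apart here. The gap between compound 1 and compound 2 could suggest that the ring nitrogen of pyridin-3-yl matters, but compound 4 shows that a ring of carbon only can sit at this position with no change beyond the scatter. Nothing shown explains this result. As far as these compounds go, whether an amine or a carboxylic acid on the ring at this position would keep numbers in this range remains open.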